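The compounds below may be only part of what the source reports. "The series", "measured", "known", "first", "only" and "open" are said of these compounds alone.

Compound 3 `Oc1nncc2cncn12` is the starting point of this step. In a functional assay for inhibition, with Homo sapiens as the target (on this read-out lower numbers stand for stronger inhibition and higher numbers for weaker inhibition), compound 3 gives > 48000 nM, which is a limit of the assay and not a number. The two other compounds measured sit at the same place. Compound 1 `Cc1ncc2cnnc(O)n12` gives > 48000 nM, again a limit. Compound 2 `CCCc1ncc2cnnc(S)n12` gives > 48000 nM, also a limit. Among the measured compounds shown here, the one measured step of a single change, a step that the two limits leave unreadable from compound 1 to compound 3, therefore cannot be read, since it joins two limits; what the data show is the limit of > 48000 nM in this assay, at which 3 of the 3 values shown sit.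

Compound 4 `CCCc1ncc2cnnc(O)n12` differs from compound 3 by propyl in place of hydrogen on an aromatic carbon, the propyl entering on an aromatic carbon of a five-membered aromatic ring with 2 nitrogen, part of a fused or bridged system of two rings. For the measured compounds named here, no measured step bears readably on this change, and the step from compound 1 to compound 3 gives no size to lean on. The step from compound 3 to compound 4 is thus expected to be a step that the limit leaves unreadable from compound 3 to compound 4, nothing readable beyond the scatter. For compound 4 the expected value in this assay is 100000 nM, within 30000 nM to 500000 nM, most likely reported only as a limit.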

Compound 4, half-maximal inhibitory concentration: > 48000 nM
Compound 4 was reported as a limit; the forecaster's own chance of this, stated with the estimate: 90%; the middle value is on the limit's open side.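

The steps from compound 1, compound 2 and compound 3 to compound 4 all join two limits and cannot be read. The compounds shown leave open which change to the shared core would give a readable value, and they end at a single place: the limit of > 48000 nM in this assay, at which 4 of the 4 values shown sit.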